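The source may report more compounds than this note shows. Statements on the series, on what has been measured and on what is new or still open speak of the compounds shown alone.

Three close relatives built on one shared core have been tested in an assay on membranes from brain for binding affinity to adenosine receptor A1 (Rattus norvegicus), read by radioligand binding, tested at 20 uM; on this read-out higher numbers stand for more inhibition at the one concentration tested (going by the name of the read-out) and lower numbers for less inhibition. Compound 1 `Cn1c(=O)[nH]c2c(cnn2-c2cc(Cl)ccc2Cl)c1=N` gives 1%. Compound 2 `Cn1c(=O)[nH]c2c(cnn2-c2ccccc2N)c1=N` gives 0%. Compound 3 `Cn1c(=O)[nH]c2c(cnn2-c2ccccc2)c1=N` gives 30%, the highest of the three numbers, standing beyond the scatter above both compound 1 and compound 2. Among the measured compounds shown here, the only single-point change among the measured compounds, hydrogen in place of amino on an aromatic carbon, gives a number 30 percentage points higher from compound 2 to compound 3 (beyond the scatter).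

Compound 4 `Cn1c(=O)[nH]c2c(cnn2-c2ccccc2Cl)c1=N` is not yet measured. It differs from compound 3 by chloro in place of hydrogen on an aromatic carbon. For the measured compounds named here, no measured step covers this exact change. Going by the values given here, compound 1 and compound 3 differ in two places at once, so their pair is no single step, but what their two values show is that the compound carrying chloro groups sits low while the one without them sits higher. On this thin basis a drop is expected for compound 4 in this assay, and its size is estimated as a number 18 percentage points lower from compound 3 to compound 4 (beyond the scatter). Compound 4 is therefore expected to give about 12%, within a range from 0% to 35%.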

Compound 4, a percentage reported as inhibition, at one concentration (the size of the read-out at that concentration, not a potency): 7%
Estimate against measurement, compound 4: 5 percentage points above; the range from low to high includes it.
By their numbers in this assay, from the lowest: compounds 2, 1 and 4 (each within the scatter of the next); then compound 3.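

On the aromatic carbon ortho to a large group, chloro in place of hydrogen gives a number 23 percentage points lower from compound 3 to compound 4 (beyond the scatter) in this assay and so shows on its own that this single change lowers the number. Chloro in place of amino at that carbon gives a number 7 percentage points higher from compound 2 to compound 4 (within the scatter) and removing a chloro group gives a number 6 percentage points higher from compound 1 to compound 4 (within the scatter) so compound 4 cannot be told apart from compound 2 or compound 1, and only compound 3, with hydrogen at this carbon, stands higher. No measurement at hand explains this drop.

As far as these compounds go, whether fluoro, methyl or methoxy at this carbon would sit as low as chloro and amino remains open. So does whether any group there could bring a number above that of compound 3 at 30% in this assay or whether it would take a change elsewhere on the ring.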